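The source may report more compounds than this note shows. Statements on the series, on what has been measured and on what is new or still open speak of the compounds shown alone.

Compound 1, `Cn1c(-c2ccc(NC(=O)CSc3nc4ccccc4o3)cc2)nc(-c2ccccc2)c1-c1ccccc1`, gives 42.3% in a functional assay on MCF7 cells (Homo sapiens) for cytotoxicity, read by MTT assay, with a stated time of 24 h, tested at 6.4 ug/mL; a lower number here means a weaker effect, a higher number a stronger effect of the compound at the concentration tested.
Compound 2, `Cc1ccc2oc(SCC(=O)Nc3ccc(-c4nc(-c5ccccc5)c(-c5ccccc5)n4C)cc3)nc2c1`, gives 24.6% in this assay.
Compound 3, `Cn1c(-c2ccc(NC(=O)CN3CCN(Cc4ccccc4)CC3)cc2)nc(-c2ccccc2)c1-c1ccccc1`, gives 23.8% in this assay.

Compounds 1 and 2 share a core and differ in one place: methyl in place of hydrogen on an aromatic carbon. That change made the step of a number 17.7 percentage points lower from compound 1 to compound 2 (beyond the scatter). Compound 3 carries a different side chain on the same amide; the difference between the core of compound 3 and that of compound 1 is not broken down here. The value of compound 3 lies within the scatter of that of compound 2, and beyond the scatter below that of compound 1.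

Compound 4, `Cc1ccc(CN2CCN(CC(=O)Nc3ccc(-c4nc(-c5ccccc5)c(-c5ccccc5)n4C)cc3)CC2)cc1`, has not yet been measured in this assay. It differs from compound 3 by methyl in place of hydrogen on an aromatic carbon. Among the measured compounds shown here, this is the same kind of change as the one from compound 1 to compound 2, though the surroundings differ: in compound 2 the methyl sits on a six-membered aromatic ring of carbon only that is part of a fused or bridged system of two rings, meta to a fused ring and para to a fused ring, whereas in compound 4 it sits on a six-membered aromatic ring of carbon only, para to a large group.

For the measured compounds named here, the single earlier step of this kind lowered the read-out. Compound 3 already starts from a low value, 23.8%, so a step of the same direction but smaller size is expected, a number 5.8 percentage points lower from compound 3 to compound 4 (within the scatter), resting on a number 17.7 percentage points lower from compound 1 to compound 2 (beyond the scatter) and on the little room left below compound 3. Compound 4 is therefore estimated at 18%, with a range from 5% to 34%.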

Compound 4, a percentage reported as activity, at one concentration (the size of the read-out at that concentration, not a potency): 21.8%
Compound 4: middle estimate off by 3.8 percentage points, on the low side; measured number inside the range.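

In this assay, methyl in place of hydrogen on an aromatic carbon gave a number 2 percentage points lower from compound 3 to compound 4 (within the scatter), so the step seen on the other core did not recur at the same size: the same change on two cores in this assay, a number 17.7 percentage points lower (beyond the scatter) from compound 1 to compound 2 and a number 2 percentage points lower (within the scatter) from compound 3 to compound 4, 15.7 percentage points apart, beyond the scatter of two such steps

In this series, therefore, the step measured on one core cannot be carried over as a fixed amount to the other, and the earlier result gives no safe guide to the size of the step on a new core. Among the compounds shown here, the comparison does not show why the two steps differ, nor does it separate the role of the core from that of the ring carrying the methyl, since the two pairs differ in both; with only two steps, it also cannot show how the change would behave on any further core.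

The compounds shown leave open whether a group other than methyl at the same place on the benzyl ring, such as a chlorine atom, a methoxy group, an amine or a carboxylic acid, would move the read-out beyond the scatter. They also leave open whether a longer chain such as ethyl in place of the methyl would do so on either core.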